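The source may hold more compounds than are shown below. What is called first, only, known or untested is meant among the compounds shown, and "the series" means these compounds.

Measured compounds:
- compound 1 `CC(C)(C)c1ccc(CNCCNS(=O)(=O)c2cc(C(F)(F)F)cc(C(F)(F)F)c2)cc1` — 14000 nM
- compound 2 `O=S(=O)(NCCNCc1ccc(-c2ccccc2)cc1)c1cc(C(F)(F)F)cc(C(F)(F)F)c1` — 2800 nM
- compound 3 `COc1ccc(CNCCCNS(=O)(=O)c2cc(C(F)(F)F)cc(C(F)(F)F)c2)cc1OC` — 6400 nM

In a functional assay on ASPC1 cells (Homo sapiens) for inhibition, read by MTT assay, with a stated time of 72 h (on this read-out higher numbers stand for weaker inhibition of growth and lower numbers for stronger inhibition of growth), compound 3 stands second highest of the three numbers: its value lies below that of compound 1 and above that of compound 2, both gaps beyond the scatter. Compound 4 `O=S(=O)(NCCCNCc1cccc(Cl)c1)c1cc(C(F)(F)F)cc(C(F)(F)F)c1` has not yet been measured in this assay. It differs from compound 3 in one place: 3-chlorophenyl in place of 3,4-dimethoxyphenyl on a saturated chain carbon bound to an amine nitrogen.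

For the measured compounds named here, the only measured step, a 5.0-fold lower number from compound 1 to compound 2 (0.70 log units; beyond the scatter), also exchanges the group on the aromatic ring at the benzyl end, though in compounds with a shorter chain and with different groups, so it bears on the present change only loosely. It shows that an exchange at that ring can move the number modestly. Going by the values given here, no measured pair exchanges methoxy groups for chlorine, so the direction of the present change is not settled by the data. The expectation for this assay is therefore a small step from compound 3 to compound 4, or none beyond the scatter, with the estimated step written as a 1.3-fold lower number from compound 3 to compound 4 (0.11 log units; within the scatter). On that basis compound 4 is estimated at 5000 nM, with a range from 1800 nM to 14000 nM.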

Compound 4, concentration for 50% growth inhibition: 5900 nM
The estimate for compound 4 lay 1.2-fold (0.07 log units) below the measured number; the range from low to high includes it.
By their numbers in this assay, from the lowest: compound 2; then compounds 4 and 3 (each within the scatter of the next); then compound 1.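

In this assay, the exchange of 3,4-dimethoxybenzyl for 3-chlorobenzyl gives a 1.1-fold lower number from compound 3 to compound 4 (0.04 log units; within the scatter), so this position accepts the loss of both methoxy groups and the entry of chlorine without a change beyond the scatter. The earlier step, a 5.0-fold lower number from compound 1 to compound 2 (0.70 log units; beyond the scatter), showed that an exchange on the aromatic ring can move the number, whereas this one shows that a substantial exchange there need not, at least on the chain shared by compound 3 and compound 4. No measurement on hand explains why this step is so small.

Still open, on these data alone, is whether a more different group on this ring, such as a carboxylic acid, a dimethylamino group or a phenyl, would also leave the number unchanged. Also open, as far as these compounds go, is what a longer chain would do to the number.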